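This account rests on a few compounds, and the source may have more. Where it says the series, first, only, none or still open, it means among the compounds named here.

Measured compounds in the series:
compound 1 `O=C1NC(=S)S/C1=C\C1=Cc2ccccc2OC1` — 52000 nM
compound 2 `O=C(O)CN1C(=O)/C(=C/C2=Cc3ccccc3OC2)SC1=S` — > 100000 nM, a limit of the assay
compound 3 `O=C1NC(=O)/C(=C/C2=Cc3cc(Br)ccc3OC2)S1` — 54700 nM

Compound 2 carries a carboxymethyl on the ring nitrogen of the shared core. In a functional assay on MOLT-4 cells (Homo sapiens) for antiproliferative activity, read by MTT assay, with a stated time of 72 h (a higher number here means a weaker inhibitor, a lower number a stronger inhibitor), compound 2 gives > 100000 nM, which is a limit of the assay and not a number (the limit of > 100000 nM in this assay, at which 1 of the 3 values shown sits). Among the compounds with values here, the only single-point step measured so far is an at least 1.9-fold higher number from compound 1 to compound 2 (0.28 log units; that floor lies within the scatter), and it concerns the carboxymethyl, not the aromatic ring.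

The next compound, compound 4 `O=C(O)CN1C(=O)/C(=C/C2=Cc3cc(Br)ccc3OC2)SC1=S`, keeps the carboxymethyl of compound 2 and differs from it in one place: bromo in place of hydrogen on an aromatic carbon. Within the data shown here, no measured step covers a bromo in isolation. Compound 1 gives 52000 nM and compound 3 gives 54700 nM; those two compounds differ in two places, and the two values lie within the usual scatter of one another, so they give no sign of an effect of the bromo. Compound 2 already sits at the limit, and nothing measured points to a step beyond the scatter in either direction. Compound 4 is expected to give 100000 nM, with a range from 50000 nM to 200000 nM, most likely again as a limit. The expected step is a number no higher from compound 2 to compound 4 (the limit leaves the size open), an estimate only.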

Compound 4, half-maximal inhibitory concentration: > 25000 nM
Compound 4 was reported as a limit (the forecaster's own chance of this, stated with the estimate: 70%); the middle value lies beyond the limit too.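

In this assay, compound 2 and compound 4 are both reported as limits of the assay and not as numbers, and the step between them cannot be read. The compounds shown leave open what bromo in place of hydrogen on an aromatic carbon does to the number in this assay when the carboxymethyl is present.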